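The source may report more compounds than this note shows. Statements on the series, on what has been measured and on what is new or still open speak of the compounds shown alone.

Measured compounds:
compound 1 `COc1cc2c(cc1N1C[C@@H](C)N(C)[C@@H](C)C1)N(C(=O)Nc1cccc(Cl)c1Cl)CC2`, 7.94 nM
compound 2 `COc1cc2c(cc1N1C[C@@H](C)N(C)[C@@H](C)C1)N(C(=O)Nc1cccc(Cl)c1F)CC2`, 7.94 nM
compound 3 `COc1cc2c(cc1N1C[C@@H](C)N(C)[C@@H](C)C1)N(C(=O)Nc1cccc(C(F)(F)F)c1F)CC2`, not yet measured

In an assay on isolated protein for binding affinity to 5-hydroxytryptamine receptor 1B (Homo sapiens) (on this read-out lower numbers stand for stronger inhibition and higher numbers for weaker inhibition), compound 1 gives 7.94 nM and compound 2 gives 7.94 nM, so compound 2 stands level with compound 1. Going by the values given here, the only measured step, no change at the digits printed from compound 1 to compound 2 (within the scatter), is a halogen swap on the same ring. Compound 3 carries a further swap there: trifluoromethyl in place of chloro on an aromatic carbon. Among the compounds with values here, since the one comparable step left this assay unchanged within the scatter, compound 3 is expected to stay close to compound 2, with the step of a 1.3-fold higher number from compound 2 to compound 3 (0.10 log units; within the scatter) expected to be small. For compound 3 the estimated value is 10 nM, with a range from 4 nM to 25 nM.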

Compound 3, inhibition constant: 3.98 nM
Compound 3: the middle estimate sits 2.5-fold (0.40 log units) above what was measured; the whole stated range lies above it.
By their numbers in this assay, from the lowest: compounds 3, 1 and 2 (each within the scatter of the next).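

In this assay, the aromatic carbon that holds chloro in compound 2 also takes trifluoromethyl, with four heavy atoms entering where one leaves, and the result is a 2.0-fold lower number from compound 2 to compound 3 (0.30 log units; within the scatter). Exchanging the whole 2,3-dichlorophenyl for 2-fluoro-3-(trifluoromethyl)phenyl gives a 2.0-fold lower number from compound 1 to compound 3 (0.30 log units; within the scatter), so neither step moves the number beyond the scatter. Nothing available explains this result. The compounds shown leave open whether a nitrile or an amine on that carbon would stay at this level. They also leave open what happens if a hydrogen takes the place of the fluoro group while trifluoromethyl stays.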